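Phenyl in place of allyl: a step to compound 4

The source may report more compounds than this note shows. Statements on the series, on what has been measured and on what is new or still open speak of the compounds shown alone.

Measured so far:
Compound 1 `O=C(Nc1ccc([Se][Se]c2ccc(NC(=O)OCc3ccccc3)cc2)cc1)OCc1ccccc1`: 100 nM
Compound 2 `C=CCOC(=O)Nc1ccc([Se]C#N)cc1`: 17600 nM
Compound 3 `O=C(Nc1ccc([Se][Se]c2ccc(NC(=O)Oc3ccccc3)cc2)cc1)Oc1ccccc1`: 5300 nM

Compound 2 was tested in a functional assay on PC-3 cells (Homo sapiens) for cytotoxicity, read by MTT assay, with a stated time of 72 h (on this read-out lower numbers stand for stronger inhibition of growth and higher numbers for weaker inhibition of growth), and gives 17600 nM, the highest number of the three, so it is the weakest of them in this assay. The nearest is compound 3 with 5300 nM, a gap beyond the scatter; the furthest is compound 1 with 100 nM. Among the compounds with values here, compounds 1 and 3 share a core that differs from the core of compound 2, so neither is a one-change neighbour of compound 2, and no single step between measured compounds is known.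

Compound 4 `N#C[Se]c1ccc(NC(=O)Oc2ccccc2)cc1` is unmeasured. It differs from compound 2 in one place: phenyl in place of allyl on an oxygen next to a carbonyl group. The only hint on this kind of exchange comes from compounds 1 and 3, where the phenyl version gives the higher number, but there the group replaced is not allyl, so that pair cannot be read as a step. With no guide from a direct neighbour, the expected step is a 2.0-fold lower number from compound 2 to compound 4 (0.29 log units; within the scatter) in this assay, small and possibly not beyond the scatter. Compound 4 is estimated at 9000 nM, with a range from 2500 nM to 30000 nM.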

Compound 4, concentration for 50% growth inhibition: 9100 nM
Compound 4: the middle estimate sits 1.0-fold (0.00 log units) below what was measured, within the range that was stated.
By their numbers in this assay, from the lowest: compound 1; then compounds 3, 4 and 2 (each within the scatter of the next, the first and the last beyond it).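

Within the data shown here, replacing allyl with phenyl on an oxygen next to a carbonyl group in this assay gives a 1.9-fold lower number from compound 2 to compound 4 (0.29 log units; within the scatter), the first reading of a single change in this set. The group leaving has 3 heavy atoms and a double bond, and the group entering has 6 heavy atoms and an aromatic ring, yet the step stays within the usual scatter, so this pair shows no clear sensitivity of the read-out to this particular exchange. No further measurement bears on this result, so the step stands as an observation without an explanation.

Going by these compounds, one pair cannot show how far that insensitivity extends, and it remains open whether an amine, a carboxylic acid or a longer chain in this place would move the number beyond the scatter. On these data alone, it also remains open whether the same exchange would give a similarly small step on the core of compound 1 , whose number lies far from those of compound 2 and compound 4 but which differs from them in more than one place.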